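Lengthening the Chain on the Core of Compound 3

The source may hold more compounds than are shown below. What is called first, only, known or untested is meant among the compounds shown, and "the series" means these compounds.

Of the compounds shown here, three have been measured in a functional assay on CCRF-CEM cells (Homo sapiens) for cytotoxicity, read by MTT assay, with a stated time of 72 h; on this read-out lower numbers stand for stronger inhibition of growth and higher numbers for weaker inhibition of growth. Compound 1 `COc1ccc(OC(=O)Nc2ccc([Se]C#N)cc2)cc1` gives 13000 nM in this assay. Compound 2 `CC(C)COC(=O)Nc1ccc([Se][Se]c2ccc(NC(=O)OCC(C)C)cc2)cc1`, built on a different core from the other two, gives 9800 nM in this assay. Compound 3 `CCCOC(=O)Nc1ccc([Se]C#N)cc1` gives 9300 nM in this assay. Compound 3 carries the lowest of the three numbers, but its gap to compound 2 and its gap to compound 1 both fall within the usual scatter of repeated measurements, so the three compounds cannot be told apart on these data.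

Compound 4 `CCCCCCOC(=O)Nc1ccc([Se]C#N)cc1` has not yet been measured. It differs from compound 3 in one place: propyl in place of hydrogen on a saturated chain carbon, three bonds along the chain from an oxygen next to a carbonyl group. Among the compounds with values here, no pair of measured compounds shares this difference, so nothing in the data sets the size of the step directly. What can be said is that the part of the molecule changed here differs among all three measured compounds, and their numbers still sit within the scatter of one another. The step from compound 3 to compound 4 is therefore expected to be small, a 1.3-fold lower number from compound 3 to compound 4 (0.12 log units; within the scatter), with no change beyond the scatter in either direction expected. For compound 4 the expected value in this assay is 7000 nM, with a range from 2500 nM to 20000 nM.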

Compound 4, concentration for 50% growth inhibition: 19700 nM
Compound 4: the middle estimate sits 2.8-fold (0.45 log units) below what was measured; measured number inside the range.
By their numbers in this assay, from the lowest: compounds 3, 2, 1 and 4 (each within the scatter of the next, the first and the last beyond it).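

In this assay, within the data shown here, this is the first step between two compounds that differ in one place only, and it reads a 2.1-fold higher number from compound 3 to compound 4 (0.33 log units; beyond the scatter). Among these compounds, it shows that the position, on a saturated chain carbon three bonds along the chain from an oxygen next to a carbonyl group, does respond to change: taking propyl to hexyl on the shared core moves the number towards weaker inhibition of growth, modestly but beyond the scatter, and so the longer chain brings no gain on this pair. No independent measurement among the data bears on why the number rises.

A single pair gives two chain lengths only, so it cannot tell whether the number climbs steadily with length or jumps at some point, and butyl, pentyl and a longer chain such as octyl would be needed to trace that course. Also open, going by these compounds, is whether the same step would hold on another core, and what a chain ending in an amine or a carboxylic acid would do at this position.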